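Chloro for methyl on the fused ring of compound 1

The compounds below may be only part of what the source reports. "The series", "measured", "known", "first", "only" and "open" are said of these compounds alone.

Compound 1 `CCN(CC)CCCn1c(=O)c(=Cc2cc(OC)c(OC)c(OC)c2)s/c1=C1\C(=O)Nc2ccc(C)cc21` carries the trimethoxyphenyl group on the double-bonded chain carbon. In a functional assay on MDA-MB-231 cells (Homo sapiens) for inhibition, read by MTT assay, with a stated time of 72 h (a higher number here means a weaker inhibitor, a lower number a stronger inhibitor), compound 1 gives only a limit, > 200000 nM, and no number; this is the limit of > 200000 nM in this assay, at which 1 of the 3 values shown sits. Compound 2 `CCN(CC)CCCn1c(=O)c(=Cc2ccc(O)cc2)s/c1=C1\C(=O)Nc2ccc(C)cc21` gives 1810 nM in this assay. Compound 3 `CCN(CC)CCCn1c(=O)c(=Cc2ccccc2O)s/c1=C1\C(=O)Nc2ccc(C)cc21` gives 15900 nM. The three measured steps all change the aryl group on that chain carbon: an at least 110-fold lower number from compound 1 to compound 2 (2.04 log units; beyond the scatter), an at least 12-fold lower number from compound 1 to compound 3 (1.09 log units; beyond the scatter), and an 8.8-fold higher number from compound 2 to compound 3 (0.94 log units; beyond the scatter).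

Compound 4 `CCN(CC)CCCn1c(=O)c(=Cc2cc(OC)c(OC)c(OC)c2)s/c1=C1\C(=O)Nc2ccc(Cl)cc21` differs from compound 1 at another place: chloro in place of methyl on an aromatic carbon. Among the measured compounds shown here, no measured step touches an aromatic carbon of the fused ring, so none of the three steps bears directly on this change, and the trimethoxyphenyl group of compound 1 is kept. Compound 1 stands at the limit of this assay, and with nothing measured on this change no step beyond the scatter is expected. The step expected for the change is a number no higher from compound 1 to compound 4 (the limit leaves the size open). Compound 4 is therefore estimated at 200000 nM, with a range from 50000 nM to 500000 nM, and is expected most likely to be reported again as a limit rather than a number.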

Compound 4, half-maximal inhibitory concentration: > 200000 nM
Compound 4 was reported as a limit; the forecaster's own chance of this, stated with the estimate: 70%; the middle value sits exactly at the limit.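

In this assay compound 4 gives > 200000 nM, a limit and not a number, and compound 1 also stands as a limit, so the step between them cannot be read: the limit of > 200000 nM in this assay, at which 2 of the 4 values shown sit.

The compounds shown leave open how chloro in place of methyl acts alongside 4-hydroxyphenyl or 2-hydroxyphenyl, the groups of compound 2 and compound 3.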